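From Carboxymethyl to Allyl: A Step Starting at a Limit

The source may report more compounds than this note shows. Statements on the series, on what has been measured and on what is new or still open speak of the compounds shown alone.

In a functional assay on A2780 cells (Homo sapiens) for antiproliferative activity, read by sulforhodamine B assay, with a stated time of 48 h (on this read-out lower numbers stand for stronger inhibition of growth and higher numbers for weaker inhibition of growth), compound 2 `CC(C)(C)[Si](C)(C)O[C@@H]1CCCO[C@@H]1COCC(=O)O` gives > 100000 nM, which is a limit of the assay and not a number. Compound 1 `CC(C)(C)[Si](C)(C)O[C@@H]1CCCO[C@@H]1CO` gives > 100000 nM, which is also a limit. Compound 2 thus stands on (the limit of > 100000 nM in this assay, at which 2 of the 3 values shown sit). Within the data shown here, compound 3 `CC(C)(C)[Si](C)(C)O[C@@H]1CCCO[C@@H]1COCC(=O)OCc1ccccc1` gives 28000 nM, the only true number of the three.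

Compound 4 `C=CCOC[C@H]1OCCC[C@H]1O[Si](C)(C)C(C)(C)C` differs from compound 2 by vinyl in place of carboxy on a saturated chain carbon bound to an oxygen on a saturated carbon, which also reads as carboxymethyl to allyl. Among the measured compounds shown here, two measured steps bear on this change. The first, a step that the two limits leave unreadable from compound 1 to compound 2, gives no size. The second, with benzyl in place of hydrogen, is an at least 3.5-fold lower number from compound 2 to compound 3 (0.55 log units; beyond the scatter), and it also leaves no free carboxy, as the change to compound 4 does. Compound 1 goes against a simple reading, since it has no carboxy group either and yet reports only the limit.

A modest move toward a lower number is therefore expected, the estimated at least 1.4-fold lower number from compound 2 to compound 4 (0.15 log units; that floor lies within the scatter). For compound 4 the estimate is 70000 nM, with an expected range from 25000 nM to 100000 nM. A report of only the limit remains about as likely as a number.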

Compound 4, concentration for 50% growth inhibition: 15000 nM
Estimate against measurement, compound 4: 4.7-fold (0.67 log units) above, and the stated range ends above it.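

In this assay, vinyl in place of carboxy on a saturated chain carbon bound to an oxygen on a saturated carbon gives an at least 6.6-fold lower number from compound 2 to compound 4 (0.82 log units; beyond the scatter), and allyl in place of hydrogen on the same oxygen gives an at least 6.6-fold lower number from compound 1 to compound 4 (0.82 log units; beyond the scatter). Compound 4 thus shows that leaving the limit at this position does not depend on the benzyl ester of compound 3, since an allyl group with no carbonyl also yields a true number, while compound 1 shows that the absence of carboxy alone does not yield one. Both steps start from a limit and not from a number, so each gives only a floor on its size: the limit of > 100000 nM in this assay, at which 2 of the 4 values shown sit.

The compounds shown leave open whether the double bond of the allyl group matters, which a saturated propyl group or a longer chain on the same oxygen would test, and whether an amine at the end of that chain would fit the same trend. As far as these compounds go, the step from compound 1 to compound 2 still cannot be read, so what carboxymethyl itself does at this oxygen also remains open.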